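This account rests on a few compounds, and the source may have more. Where it says the series, first, only, none or still open, it means among the compounds named here.

Compound 1, `CC(C)=CCC/C(C)=C/CC1Cc2c(OC(=O)Nc3ccccc3F)cc(=O)n(CCCO)c2CC1(C)C`, gives 0% in a functional assay on PANC-1 cells (Homo sapiens) for inhibition, read by MTT assay, with a stated time of 24 h, tested at 10 uM; on this read-out lower numbers stand for less inhibition and higher numbers for more inhibition at the one concentration tested (going by the name of the read-out). For the measured compounds named here, compound 2, `CC(C)=CCC/C(C)=C/CC1Cc2c(OC(=O)Nc3ccc(F)cc3F)cc(=O)n(CCCO)c2CC1(C)C`, gives 15.6% in this assay, which puts compound 2 highest of the two numbers measured so far, with compound 1 as its nearest neighbour. Going by the values given here, the one measured step, a number 15.6 percentage points higher from compound 1 to compound 2 (beyond the scatter), came with fluoro in place of hydrogen on an aromatic carbon, a modest rise.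

Compound 3, `CC(C)=CCC/C(C)=C/CC1Cc2c(OC(=O)Nc3ccc(Cl)c(Cl)c3)cc(=O)n(CCCO)c2CC1(C)C`, has not yet been measured. It differs from compound 2 by 3,4-dichlorophenyl in place of 2,4-difluorophenyl on an amide-type nitrogen. Among the compounds with values here, the only step that bears on this change is the one from compound 1 to compound 2, where a second halogen on the phenyl ring of the carbamate raised inhibition modestly. Within the data shown here, no measured compound carries chlorine, and no measured step exchanges one halogen pattern for another, so that step is only a loose guide. Compound 3 is therefore expected to sit close to compound 2, with a step of about a number 4.4 percentage points higher from compound 2 to compound 3 (within the scatter), which is within the scatter and could fall on either side. Compound 3 is estimated to give 20% in this assay, within a range from 5% to 40%.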

Compound 3, a percentage reported as inhibition, at one concentration (the size of the read-out at that concentration, not a potency): 0%
Compound 3: middle estimate off by 20 percentage points, on the high side; the whole stated range lies above it.
By their numbers in this assay, from the lowest: compounds 1 and 3 (each within the scatter of the next); then compound 2.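

Exchanging 2,4-difluorophenyl for 3,4-dichlorophenyl on the amide-type nitrogen came with a number 15.6 percentage points lower from compound 2 to compound 3 (beyond the scatter) in this assay, so carrying two halogens on this ring was not enough to keep the inhibition seen with compound 2. Replacing the 2-fluorophenyl group at the same nitrogen with 3,4-dichlorophenyl gave no change at the digits printed from compound 1 to compound 3 (within the scatter), which means that the ring with two chlorines could not be told apart from the ring with one fluorine. Among these three compounds, only the 2,4-difluorophenyl group of compound 2 stands apart, and this place on the molecule therefore responds to which halogens the ring carries and where, not simply to how many. No measurement shown here explains this difference between the aryl groups.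

The step from compound 2 to compound 3 changes both the halogen and its placement on the ring, so 3,4-difluorophenyl and 2,4-dichlorophenyl would be needed to separate the two changes. The compounds also leave open whether the response extends beyond halogens, for example to a 4-methoxyphenyl group, a 4-cyanophenyl group or an aliphatic cyclohexyl group on this nitrogen.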